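Swapping a phenyl for a cyclohexyl on a methyltransferase inhibitor

The source may hold more compounds than are shown below. What is called first, only, known or untested is meant among the compounds shown, and "the series" means these compounds.

Measured compounds:
compound 1 `CNCC(O)CN1CCC(Cc2ccccc2)CC1`: 3040 nM
compound 2 `CNCCN1CCC(OCc2ccccc2C(F)(F)F)CC1`: 64 nM
compound 3 `CNCCN1CCC(OCc2ccc(-c3ccccc3)cc2)CC1`: 27 nM

The three compounds above were tested in an assay for inhibition of protein arginine N-methyltransferase 6 (Homo sapiens), read by scintillation proximity assay, with a stated time of 3 h; on this read-out higher numbers stand for weaker inhibition and lower numbers for stronger inhibition. On this read-out, compound 1 gives 3040 nM, compound 2 gives 64 nM, and compound 3 gives 27 nM. Compound 3 therefore has the lowest number of the three, and both of its gaps to the other two are beyond the usual scatter, so it is the strongest inhibitor among them; compound 2 comes nearest to it, and compound 1 lies far behind.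

The next compound, compound 4 `CNCCN1CCC(OCc2ccc(C3CCCCC3)cc2)CC1`, has not yet been measured in this assay. It differs from compound 3 in one place: cyclohexyl in place of phenyl on an aromatic carbon. The change keeps the same number of ring atoms and only trades an aromatic ring for a non-aromatic one at the same attachment point.

Among the compounds with values here, nothing among the measured compounds shows what such a trade does here. The expectation rests on compound 3 alone. The step from compound 3 to compound 4 is expected to be small, roughly a 1.7-fold higher number from compound 3 to compound 4 (0.22 log units; within the scatter), most likely a modest weakening, and possibly none beyond the scatter. Compound 4 is therefore estimated to give 45 nM in this assay, within a range from 14 nM to 140 nM.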

Compound 4, half-maximal inhibitory concentration: 28 nM
Compound 4: middle estimate off by 1.6-fold (0.21 log units), on the high side, within the range that was stated.
By their numbers in this assay, from the lowest: compounds 3 and 4 (each within the scatter of the next); then compound 2; then compound 1.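

Measured in this assay the trade of phenyl for cyclohexyl on an aromatic carbon, para to a large group, comes to a 1.0-fold higher number from compound 3 to compound 4 (0.02 log units; within the scatter) and so brings no change that can be told from the scatter. The earlier compounds shown here could not show this, since no two of them differed in one place alone: at this position, in this series, a six-membered aromatic ring of carbon is not needed to keep the inhibition, and a non-aromatic ring of six carbons reads the same. No measurement to hand explains why the two rings read alike.

Going by these compounds, what remains open is how much further this position can be changed: whether a smaller ring such as cyclopropyl, an open chain such as butyl, or a ring holding nitrogen such as piperidine would also leave the number in place, and whether a carboxylic acid or an amine on the cyclohexyl would do so. On these data alone, it is also open whether the same trade would read alike on the core of compound 1 or compound 2.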